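The source may hold more compounds than are shown below. What is called first, only, known or untested is meant among the compounds shown, and "the series" means these compounds.

Measured so far:
- compound 1 `Cn1nc2c(=O)n(CC3(O)CCN(Cc4ccc(-c5ccco5)cc4Cl)CC3)cnc2c1-c1ccc(C2(N)CC2)cc1` gives 66.1 nM
- compound 2 `Cn1nc2c(=O)n(CC3(O)CCN(Cc4ccc(-n5ccnc5)cc4Cl)CC3)cnc2c1-c1ccc(CN)cc1` gives 228 nM

In an assay on isolated protein for inhibition of ubiquitin carboxyl-terminal hydrolase 7 (Homo sapiens), with stated times of 30 min and 2 h (on this read-out lower numbers stand for stronger inhibition and higher numbers for weaker inhibition), compound 1 has the lowest number of the two, and compound 2 stands clearly higher, beyond the usual scatter. Compound 3 `Cn1nc2c(=O)n(CC3(O)CCN(Cc4ccc(-c5ccco5)cc4Cl)CC3)cnc2c1-c1ccc(CO)cc1` has not yet been measured. It differs from compound 1 in one place: hydroxymethyl in place of 1-aminocyclopropyl on an aromatic carbon. Going by the values given here, no measured pair shows this change, so the step in this assay is expected to be modest and toward a higher number, though it could fall within the scatter. Compound 3 is expected at about 150 nM, from 50 nM to 500 nM. This estimate means a step of a 2.3-fold higher number from compound 1 to compound 3 (0.36 log units; beyond the scatter).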

Compound 3, half-maximal inhibitory concentration: 42.5 nM
Estimate against measurement, compound 3: 3.5-fold (0.55 log units) above; measured number below the stated range.
By their numbers in this assay, from the lowest: compounds 3 and 1 (each within the scatter of the next); then compound 2.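

In this assay, hydroxymethyl in place of 1-aminocyclopropyl on this aromatic carbon gives a 1.6-fold lower number from compound 1 to compound 3 (0.19 log units; within the scatter) and so leaves the read-out unchanged within the scatter. This position therefore accepts a group with no ring and no nitrogen, and with 2 heavy atoms rather than 4, without a detectable loss. Nothing measured here explains why the two groups read alike. Still open, on these data alone, is whether the oxygen of hydroxymethyl matters at this position. A plain methyl or a carboxylic acid at the same place would test that.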